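The source may report more compounds than this note shows. Statements on the series, on what has been measured and on what is new or still open speak of the compounds shown alone.

In an assay on cells for agonist activity at ecdysone receptor (Bombyx mori), read by a luciferase reporter, with a stated time of 24 h (a lower number here means that less compound is needed, a higher number that more compound is needed for the effect), compound 1 `CC(C)(C)N(NC(=O)c1ccc(Br)cc1)C(=O)c1ccccc1Cl` gives 33.9 nM. Compound 2 `CC(C)(C)N(NC(=O)c1ccc(C#N)cc1)C(=O)c1ccccc1Cl` gives 603 nM, and compound 3 `CC(C)(C)N(NC(=O)c1cccc(Cl)c1Cl)C(=O)c1ccccc1Cl` gives 9.33 nM. Compound 3 thus has the lowest number of the three: the step is a 3.6-fold lower number from compound 1 to compound 3 (0.56 log units; beyond the scatter), and a 65-fold lower number from compound 2 to compound 3 (1.81 log units; beyond the scatter). Compound 4 `Cc1cccc(C(=O)NN(C(=O)c2ccccc2Cl)C(C)(C)C)c1C` has not yet been measured in this assay. Its difference from compound 3 is 2,3-dimethylphenyl in place of 2,3-dichlorophenyl on a carbonyl carbon. Among the compounds with values here, no measured step exchanges chlorine for methyl, so the available steps bear on it only indirectly. The step of an 18-fold higher number from compound 1 to compound 2 (1.25 log units; beyond the scatter) shows that this part of the molecule can move the number a great deal, while a 3.6-fold lower number from compound 1 to compound 3 (0.56 log units; beyond the scatter) shows that the move to the 2,3-dichlorophenyl pattern lowered it. Since the 2,3-substitution pattern is kept and only the identity of the two groups changes, the expected step is small: compound 4 is expected to give 20 nM, between 6 nM and 70 nM, with the expected step of a 2.1-fold higher number from compound 3 to compound 4 (0.33 log units; beyond the scatter) pointing slightly toward a higher number.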

Compound 4, half-maximal effective concentration: 20 nM
The estimate for compound 4 equals the measured number at the digits printed, and the stated range covers the measured number.
By their numbers in this assay, from the lowest: compound 3; then compounds 4 and 1 (each within the scatter of the next); then compound 2.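

In this assay, the change from the 2,3-dichlorophenyl to the 2,3-dimethylphenyl group (a 2.1-fold higher number from compound 3 to compound 4 (0.33 log units; beyond the scatter)) shows that a low number at this carbonyl carbon does not depend on chlorine, although compound 3 keeps a modest lead over compound 4. The 2,3-dimethylphenyl group also stands far from the 4-cyanophenyl group (a 30-fold lower number from compound 2 to compound 4 (1.48 log units; beyond the scatter)), so a large gap from compound 2 is not unique to compound 3. Against the 4-bromophenyl group, however, the new group is not separated (a 1.7-fold lower number from compound 1 to compound 4 (0.23 log units; within the scatter)), so only the 2,3-dichlorophenyl group lies clear of compound 1.

Going by these compounds, whether two methoxy groups, two fluorines or a single methyl group on this phenyl ring would keep the number low remains open. Nothing available explains the step between compound 3 and compound 4.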